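The source may report more compounds than this note shows. Statements on the series, on what has been measured and on what is new or still open speak of the compounds shown alone.

Three compounds have been measured in a functional assay on HepG2 cells (Homo sapiens) for inhibition, read by MTT assay, with a stated time of 72 h; a higher number here means a weaker inhibitor, a lower number a stronger inhibitor:

compound 1 `COc1cc(O)c(CC=C(C)C)c(O)c1C(=O)/C=C/c1ccc(Cl)cc1` — 10100 nM
compound 2 `COc1cc(O)c(CC=C(C)C)c(O)c1C(=O)/C=C/c1ccc(C(F)(F)F)cc1` — 6500 nM
compound 3 `COc1cc(OC)c(C(=O)/C=C/c2ccc(C(F)(F)F)cc2)c(OC)c1` — 9700 nM

Compound 1 and compound 2 share one core and differ in a single place: the change from compound 2 to compound 1 is chloro in place of trifluoromethyl on an aromatic carbon. In this assay it made a 1.6-fold higher number from compound 2 to compound 1 (0.19 log units; within the scatter), a step that does not stand out from the ordinary spread of such measurements.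

Compound 3 is built on a different core. How its core differs from that of compound 2 is not broken down here. In this assay the numbers for compound 3 and compound 2 lie within the usual scatter of each other, and the same holds for compound 3 and compound 1.

Compound 4 `COc1cc(OC)c(C(=O)/C=C/c2ccc(Cl)cc2)c(OC)c1` has not yet been measured. It is related to compound 3 exactly as compound 1 is related to compound 2: the change is chloro in place of trifluoromethyl on an aromatic carbon, and the surroundings of the place are described in the same words as for the earlier pair, so this is the same change, occurring twice among these compounds.

Going by the values given here, the step from compound 3 to compound 4 in this assay is expected to be about a 1.3-fold higher number from compound 3 to compound 4 (0.13 log units; within the scatter), resting on the single earlier instance, which gave a 1.6-fold higher number from compound 2 to compound 1 (0.19 log units; within the scatter). Compound 4 is therefore estimated to give about 13000 nM, most likely between 6000 nM and 28000 nM.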

Compound 4, half-maximal inhibitory concentration: 12400 nM
Estimate against measurement, compound 4: 1.0-fold (0.02 log units) above; the measured number falls inside the stated range.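

In this assay, putting chloro in place of trifluoromethyl on the aromatic carbon gave a 1.3-fold higher number from compound 3 to compound 4 (0.11 log units; within the scatter), so this step, like the earlier one, does not stand out from the ordinary spread of repeated measurements. Set side by side, the two instances agree, which means that in these four compounds the change behaves alike on both cores: the same change on two cores in this assay, a 1.6-fold higher number (0.19 log units; within the scatter) from compound 2 to compound 1 and a 1.3-fold higher number (0.11 log units; within the scatter) from compound 3 to compound 4, 1.2-fold (0.08 log units) apart, within the scatter of two such steps

This does not show that the change has a real effect of its own in this assay, as both steps lie within the scatter, and two pairs on two cores cannot speak for any further core.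

The compounds shown carry only chloro and trifluoromethyl at this place on the ring, so it remains open whether a different group there, such as an amine, a nitrile or a carboxylic acid, would give a step that clearly exceeds the scatter. From the compounds shown here alone, the two cores also differ in ways that are not broken down into single changes here, so what each of those differences contributes remains open too.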